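Replacing methylsulfanyl with cyano in an MTT series

The source may report more compounds than this note shows. Statements on the series, on what has been measured and on what is new or still open speak of the compounds shown alone.

Compound 1 `COc1ccc(-c2nc3ccccn3c2Sc2ccccc2)cc1`: 58400 nM
Compound 2 `CSc1ccc(-c2nc3ccccn3c2Sc2ccccc2)cc1`: 13600 nM
Compound 3 `N#Cc1ccc(-c2nc3ccccn3c2Sc2ccccc2)cc1`: not yet measured

Among the measured compounds shown here, in a functional assay on A549 cells (Homo sapiens) for inhibition, read by MTT assay, with a stated time of 48 h (on this read-out lower numbers stand for stronger inhibition and higher numbers for weaker inhibition), compound 2 gives 13600 nM, the lower of the two numbers so far, while compound 1 gives 58400 nM. Compound 3 keeps the core of compound 2 and carries cyano in place of methylsulfanyl on an aromatic carbon, para to a large group: cyano in place of methylsulfanyl on an aromatic carbon. For the measured compounds named here, one measured step bears on this place: a 4.3-fold lower number from compound 1 to compound 2 (0.63 log units; beyond the scatter), a modest change beyond the scatter. Going by the values given here, no cyano compound has been measured, so this single step is a thin guide. A modest step of similar size, towards a higher number, is expected. The estimated step is a 2.2-fold higher number from compound 2 to compound 3 (0.34 log units; beyond the scatter). For compound 3 the expected value is 30000 nM, with an estimated range from 10000 nM to 80000 nM.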

Compound 3, half-maximal inhibitory concentration: 35200 nM
For compound 3 the middle estimate is 1.2-fold (0.07 log units) below the measured one, and the stated range covers the measured number.
By their numbers in this assay, from the lowest: compound 2; then compounds 3 and 1 (each within the scatter of the next).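

In this assay, the change from 4-(methylsulfanyl)phenyl to 4-cyanophenyl gives a 2.6-fold higher number from compound 2 to compound 3 (0.41 log units; beyond the scatter), so methylsulfanyl now stands apart at this place from a second group and not only from methoxy. Cyano and methoxy are not separated, since a 1.7-fold lower number from compound 1 to compound 3 (0.22 log units; within the scatter) lies within the scatter, and of the three groups on this aromatic carbon only the methylsulfanyl of compound 2 differs beyond the scatter from both others. Nothing measured on these compounds accounts for the gap between methylsulfanyl and the other two groups. The compounds shown leave open whether the sulfur atom itself matters, which a longer chain on sulfur, such as ethylsulfanyl, or a plain methyl group could begin to test. They also leave open how an amine or a carboxylic acid would read at this place.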